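The source may report more compounds than this note shows. Statements on the series, on what has been measured and on what is new or still open speak of the compounds shown alone.

In an in vitro ADME assay on microsomes from liver (Homo sapiens) for metabolic stability, using NADPH (on this read-out lower numbers stand for slow clearance and higher numbers for fast clearance), compound 1 `CC(C)(CO)CNC(=O)c1cc2cc(C#N)ccc2n1Cc1cccc(OC(F)(F)F)c1` gives 62 mL.min-1.g-1. Compound 2 `COc1ccc(OC(F)(F)F)cc1Cn1c(C(=O)NCC(C)(C)CO)cc2cc(C#N)ccc21` gives 69 mL.min-1.g-1, so compound 1 and compound 2 together sit at the low end of the three numbers, while compound 3 `CCCOc1cccc(Cn2c(C(=O)NCC(C)(C)CO)cc3cc(C#N)ccc32)c1` gives 156 mL.min-1.g-1. Compound 4 `CC(O)CCNC(=O)c1cc2cc(C#N)ccc2n1Cc1cccc(OC(F)(F)F)c1` has not been measured yet. It keeps the core of compound 1 and alters only the chain on the amide-type nitrogen: 2-hydroxypropyl in place of 1-(hydroxymethyl)-1-methylethyl on a saturated chain carbon bound to an amide-type nitrogen. Two measured steps offer only indirect guidance. Methoxy in place of hydrogen on an aromatic carbon gave a 1.1-fold higher number from compound 1 to compound 2 (0.05 log units; within the scatter), and propyl in place of trifluoromethyl on an oxygen on an aromatic ring gave a 2.5-fold higher number from compound 1 to compound 3 (0.40 log units; beyond the scatter). Neither step touches the amide chain, so the data do not show directly what this swap does. With no such evidence, no step beyond the scatter is expected in this assay. The expected step is a 1.1-fold higher number from compound 1 to compound 4 (0.05 log units; within the scatter). For compound 4 the estimated value is 70 mL.min-1.g-1. The expected range for compound 4 runs from 35 mL.min-1.g-1 to 130 mL.min-1.g-1.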

Compound 4, intrinsic clearance in microsomes: 113 mL.min-1.g-1
The estimate for compound 4 lay 1.6-fold (0.21 log units) below the measured number; low and high end bracket the measured number.
By their numbers in this assay, from the lowest: compounds 1, 2, 4 and 3 (each within the scatter of the next, the first and the last beyond it).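

Going by these compounds alone, compound 4 gives the first measured look at the chain on the amide-type nitrogen, as the earlier steps changed only the other end of the molecule. In this assay, 2-hydroxypropyl in place of 1-(hydroxymethyl)-1-methylethyl gives a 1.8-fold higher number from compound 1 to compound 4 (0.26 log units; within the scatter), a step that stays within the usual scatter, so this one pair does not separate the two chains, even though the 5 heavy atoms of the old group become 4 in the new one. Nothing measured here accounts for the size of this step.

The compounds shown leave open how a longer chain, or an amine or a carboxylic acid in place of the hydroxyl on this chain, would read in this assay. They also leave open whether the 2-hydroxypropyl swap would give a similar step on the core of compound 3.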